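Series notes: from compound 2 toward compound 3

The source may hold more compounds than are shown below. What is called first, only, known or untested is meant among the compounds shown, and "the series" means these compounds.

Compound 1 `COc1ccc(C(=O)/C=C/c2cc(OC)c(OC)c(OC)c2)c2c1C=CC(C)(C)O2` in a functional assay on HepG2 cells (Homo sapiens) for antiproliferative activity, read by MTT assay, with a stated time of 24 h (on this read-out lower numbers stand for stronger inhibition and higher numbers for weaker inhibition), gives only a limit, > 10000 nM. Within the data shown here, compound 2 `COc1ccc(C(=O)/C=C/c2ccc(N(C)C)cc2)c2c1C=CC(C)(C)O2` gives 730 nM in this assay, the single number in the set. One further value sits at the limit of > 10000 nM in this assay, at which 1 of the 2 values shown sits. Compound 3 `COc1ccc(C(=O)/C=C/c2cc(Cl)ccc2O)c2c1C=CC(C)(C)O2` carries 5-chloro-2-hydroxyphenyl in place of 4-(dimethylamino)phenyl on a double-bonded chain carbon bound to a double-bonded chain carbon. Among the measured compounds shown here, no measured pair differs in one place, so no measured step sets a size for this change. The expected step from compound 2 to compound 3 is a 4.1-fold higher number from compound 2 to compound 3 (0.61 log units; beyond the scatter), toward weaker inhibition, beyond the scatter. Compound 3 is estimated at 3000 nM, within 800 nM to 12000 nM.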

Compound 3, half-maximal inhibitory concentration: 6640 nM
Estimate against measurement, compound 3: 2.2-fold (0.35 log units) below, within the range that was stated.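

Among these compounds, this is the first measured step at this position: in this assay, 5-chloro-2-hydroxyphenyl in place of 4-(dimethylamino)phenyl on a double-bonded chain carbon bound to a double-bonded chain carbon gives a 9.1-fold higher number from compound 2 to compound 3 (0.96 log units; beyond the scatter), toward weaker inhibition. Compound 3 still returns a number, so activity here does not depend entirely on the dimethylamino group. Compound 1 stands only as a limit of the assay: the limit of > 10000 nM in this assay, at which 1 of the 3 values shown sits.

The chlorine, the hydroxyl and the loss of the dimethylamino group form one change, and their separate shares cannot be read. On these data alone, whether 4-(diethylamino)phenyl in the same place would match compound 2 stays open.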